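Compound 3 to compound 4: methyl to ethoxy

The compounds below may be only part of what the source reports. "The series", "measured", "known", "first", "only" and "open" are said of these compounds alone.

Measured so far in a functional assay on CCRF-CEM cells (Homo sapiens) for antiproliferative activity; on this read-out higher numbers stand for weaker inhibition and lower numbers for stronger inhibition:
- compound 1 `COc1ccc(-c2cc(N)c(C(=O)c3cc(OC)c(OC)c(OC)c3)s2)cc1OC`: 20 nM
- compound 2 `COc1cc(C(=O)c2sc(-c3ccncc3)cc2N)cc(OC)c1OC`: 110 nM
- compound 3 `COc1cc(C(=O)c2sc(-c3ccc(C)cc3)cc2N)cc(OC)c1OC`: 15 nM

Compound 3 holds the lowest number of the three, but its lead over its nearest neighbour is not a real separation: a 1.3-fold lower number from compound 1 to compound 3 (0.12 log units; within the scatter). The next entry, compound 4 `CCOc1ccc(-c2cc(N)c(C(=O)c3cc(OC)c(OC)c(OC)c3)s2)cc1`, differs from it as follows: ethoxy in place of methyl on an aromatic carbon. The closest measured precedent is that same step between 3,4-dimethoxyphenyl and 4-methylphenyl. The larger steps, a 5.5-fold higher number from compound 1 to compound 2 (0.74 log units; beyond the scatter) and a 7.3-fold lower number from compound 2 to compound 3 (0.87 log units; beyond the scatter), involve pyridin-4-yl, which plays no part here. The estimated change is no change at the digits printed from compound 3 to compound 4 (within the scatter), so no step beyond the scatter is expected in this assay. Compound 4 is estimated at 15 nM, with an expected range of 5 nM to 50 nM.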

Compound 4, half-maximal inhibitory concentration: 270 nM
The estimate for compound 4 lay 18-fold (1.26 log units) below the measured number; the whole stated range lies below it.
By their numbers in this assay, from the lowest: compounds 3 and 1 (each within the scatter of the next); then compound 2; then compound 4.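

For the compounds shown here, in (this assay), the group para to a large group is less forgiving than the earlier compounds suggested: 4-ethoxyphenyl costs heavily against 4-methylphenyl (an 18-fold higher number from compound 3 to compound 4 (1.26 log units; beyond the scatter)) and against 3,4-dimethoxyphenyl (a 14-fold higher number from compound 1 to compound 4 (1.13 log units; beyond the scatter)). It also falls behind pyridin-4-yl (a 2.5-fold higher number from compound 2 to compound 4 (0.39 log units; beyond the scatter)), so the earlier highest number no longer marks the limit at this position. Nothing at hand accounts for this loss.

Open, on these data alone, is whether the ethoxy oxygen or the chain length matters more. 4-Ethylphenyl, 4-methoxyphenyl and 4-propoxyphenyl would help separate the two.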